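Stretching the Linker Toward the Reactive Arm

This account rests on a few compounds, and the source may have more. Where it says the series, first, only, none or still open, it means among the compounds named here.

Three compounds have been measured in an assay on isolated protein for inhibition of hexokinase-3 (Rattus norvegicus), with a stated time of 6 h, tested at 10 mM; on this read-out lower numbers stand for less inhibition and higher numbers for more inhibition at the one concentration tested (going by the name of the read-out):
compound 1, `CN(CCCCN(C)C(=O)CCCCNc1ncnc2c1ncn2[C@@H]1O[C@H](COP(=O)(O)OP(=O)(O)OP(=O)(O)O)[C@@H](O)[C@H]1O)C(=O)CCCCNC(=O)CI`, gives 0%;
compound 2, `Nc1ncnc2c1nc(NCCCCNC(=O)CI)n2[C@@H]1O[C@H](COP(=O)(O)OP(=O)(O)OP(=O)(O)O)[C@@H](O)[C@H]1O`, gives 0%;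
compound 3, `O=C(CI)NCCCCCCCNc1ncnc2c1ncn2[C@@H]1O[C@H](COP(=O)(O)OP(=O)(O)OP(=O)(O)O)[C@@H](O)[C@H]1O`, gives 20%.

Compound 2 stands level with compound 1 at the digits shown, and together they are the lowest of the three numbers. Compound 3 lies higher than compound 2, a gap that goes beyond the usual scatter of this measurement.

The next compound, compound 4, `Nc1ncnc2c1nc(NCCCCCCNC(=O)CI)n2[C@@H]1O[C@H](COP(=O)(O)OP(=O)(O)OP(=O)(O)O)[C@@H](O)[C@H]1O`, is compound 2 with one change: 2-(((iodomethyl)carbonyl)amino)ethyl in place of ((iodomethyl)carbonyl)amino on a saturated chain carbon, four bonds along the chain from a nitrogen on an aromatic ring. The entering group is the longer of the two, so the reactive arm sits further from the shared core.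

Among the measured compounds shown here, no pair of measured compounds differs in exactly this way, so there is no measured step to lean on. Compound 3, which also carries a longer chain, gives 20%, while compound 2 gives 0%, and this is the only hint that a longer linker may lift the read-out. The expected step of a number 5 percentage points higher from compound 2 to compound 4 (within the scatter) is therefore small and upward, at most on the edge of the scatter. Compound 4 is estimated at 5%, within a range from 0% to 20%.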

Compound 4, a percentage reported as inhibition, at one concentration (the size of the read-out at that concentration, not a potency): 0%
The estimate for compound 4 lay 5 percentage points above the measured number, within the range that was stated.
By their numbers in this assay, from the lowest: compounds 1, 2 and 4 (each within the scatter of the next); then compound 3.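

Putting 2-(((iodomethyl)carbonyl)amino)ethyl in place of ((iodomethyl)carbonyl)amino on a saturated chain carbon, four bonds along the chain from a nitrogen on an aromatic ring, gives no change at the digits printed from compound 2 to compound 4 (within the scatter) in this assay. Among the compounds shown here, this is the first direct test of chain length at this position, and this lengthening alone, with the shared core unchanged, leaves the read-out where it was. No other data here bear on this result.

As far as these compounds go, compound 2 and compound 4 both sit at the bottom of the read-out, so it remains open whether a longer chain at this position, such as 4-(((iodomethyl)carbonyl)amino)butyl, would give any measurable inhibition. From the compounds shown here alone, it is also open how the read-out would respond if an amine or a carboxylic acid replaced the iodomethyl carbonyl end of the chain.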